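Exchanging one five-membered aromatic ring on compound 2

The compounds below may be only part of what the source reports. "The series", "measured", "known", "first", "only" and "open" are said of these compounds alone.

Of the compounds shown here, three sharing one core have numbers so far. In a functional assay on A549 cells (Homo sapiens) for antiproliferative activity, read by MTT assay, with a stated time of 72 h (on this read-out lower numbers stand for stronger inhibition and higher numbers for weaker inhibition), compound 1 `Cn1cc(-c2nn(Cc3ccc(C(=O)N4CCCCC4)cc3)c(=O)c3ccccc23)cn1` gives 67400 nM while compound 2 `Cn1cc(-c2nn(Cc3ccc(C(=O)NC4CCCC4)cc3)c(=O)c3ccccc23)cn1` gives 32300 nM and compound 3 `Cn1cc(-c2nn(Cc3ccc(C(=O)NC4CC4)cc3)c(=O)c3ccccc23)cn1` gives 51200 nM as its value. Within the data shown here, only one step among them clears the scatter, and a 2.1-fold lower number from compound 1 to compound 2 (0.32 log units; beyond the scatter) is a modest one. Both a 1.6-fold higher number from compound 2 to compound 3 (0.20 log units; within the scatter) and a 1.3-fold lower number from compound 1 to compound 3 (0.12 log units; within the scatter) stay within it. So compound 2 can be told apart from compound 1 but not from compound 3.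

Compound 4 `Cc1noc(C)c1-c1nn(Cc2ccc(C(=O)NC3CCCC3)cc2)c(=O)c2ccccc12` keeps the cyclopentylamino group of compound 2 but carries 3,5-dimethyl-1,2-oxazol-4-yl in place of 1-methyl-1H-pyrazol-4-yl on an aromatic carbon of the core, and 3,5-dimethyl-1,2-oxazol-4-yl in place of 1-methyl-1H-pyrazol-4-yl on an aromatic carbon sums up the change. Among the measured compounds shown here, none of the measured steps touches that place, since each alters only the group on the carbonyl carbon. They are all small, yet they say nothing direct about this exchange, and the data give no direction for it. No shift beyond the scatter is therefore expected in this assay for this exchange. The expected step is a 1.5-fold lower number from compound 2 to compound 4 (0.17 log units; within the scatter) and it is a rough expectation only. Compound 4 is estimated at 22000 nM with a likely range from 7000 nM to 70000 nM on this reasoning.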

Compound 4, half-maximal inhibitory concentration: > 100000 nM
Compound 4: no number, only a limit; the forecaster's own chance of this, stated with the estimate: 10%; at least 4.5-fold (0.65 log units) between middle value and limit.
By their numbers in this assay, from the lowest: compounds 2, 3 and 1 (each within the scatter of the next, the first and the last beyond it). At a limit, above all of these: compound 4.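

In this assay compound 4 gives > 100000 nM, which is a limit of the assay and not a number. Among these compounds, the earlier steps all altered the group on the carbonyl carbon, whereas this is the only change at the aromatic carbon next to the ring nitrogen, and 3,5-dimethyl-1,2-oxazol-4-yl in place of 1-methyl-1H-pyrazol-4-yl gives an at least 3.0-fold higher number from compound 2 to compound 4 (0.49 log units; beyond the scatter), showing that this position responds to the exchange even though both groups are five-membered aromatic rings with 2 hetero atoms. The true size of this step cannot be read, and the firm reading is the limit itself: the limit of > 100000 nM in this assay, at which 1 of the 4 values shown sits.

The exchange alters the ring and its methyl groups together, so the compounds shown leave open which of these matters, and a 3,5-dimethyl-1H-pyrazol-4-yl group or a plain 1,2-oxazol-4-yl group at this place would help to separate the two. Also open, as far as these compounds go, is whether the same exchange has a similar effect when the cyclopentylamino group of compound 2 is replaced by the piperidin-1-yl group of compound 1.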